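The source may report more compounds than this note shows. Statements on the series, on what has been measured and on what is new or still open speak of the compounds shown alone.

Compound 1, `CCCCCCc1cc2cn(COCCO)c(O)nc-2n1`, stands at the upper edge of what has been seen in a functional assay on HEL cells (Homo sapiens), read by microscopy; on this read-out lower numbers stand for higher toxicity in this test and higher numbers for lower toxicity in this test. In this assay compound 1 gives > 400000 nM, which is a limit of the test and not a number. Compound 2, `CO[C@H]1[C@H](O)[C@@H](O)[C@@H](O)O[C@@H]1C(=O)O`, also gives in this assay only a limit, > 100000 nM. Both results rest on limits: the limit of > 100000 nM in this assay, at which 1 of the 2 values shown sits, and (the limit of > 400000 nM in this assay, at which 1 of the 2 values shown sits). Compound 3, `CCCCc1cc2cn(COCCO)c(O)nc-2n1`, has not yet been measured; it differs from compound 1 by hydrogen in place of ethyl on a saturated chain carbon, four bonds along the chain from an aromatic carbon. In this assay a step of a number no higher from compound 1 to compound 3 (the limit leaves the size open) is expected, none beyond the scatter. Compound 3 is therefore estimated at 400000 nM, between 100000 nM and 1000000 nM.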

Compound 3, minimum cytotoxic concentration: > 400000 nM
Compound 3: a limit, no number; the forecaster's own chance of this, stated with the estimate: 85%; the middle value sits exactly at the limit.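

Going by these compounds alone, compound 1 and compound 3 both rest on a limit in this assay, so no step between them can be read: the limit of > 400000 nM in this assay, at which 2 of the 3 values shown sit. The compounds shown leave open whether hydrogen in place of ethyl changes the read-out at all.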